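Adding a Second Chloro to a Urea-Linked Phenyl Ring

The source may report more compounds than this note shows. Statements on the series, on what has been measured and on what is new or still open speak of the compounds shown alone.

Compound 1 `CN(C)CCNc1nc(-c2ccc(NC(=O)Nc3ccccc3)cc2)nc2ccsc12` gives 620 nM in a functional assay on HT-29 cells (Homo sapiens) for cytotoxicity, read by MTT assay, with a stated time of 72 h; a higher number here means a weaker inhibitor, a lower number a stronger inhibitor. Compound 2 `CN(C)CCNc1nc(-c2ccc(NC(=O)Nc3ccccc3Cl)cc2)nc2ccsc12` carries one change, (chloro in place of hydrogen on an aromatic carbon), and in this assay compound 2 gives 310 nM, a step of a 2.0-fold lower number from compound 1 to compound 2 (0.30 log units; within the scatter). Compound 3 `CCN(CC)CCNc1nc(-c2ccc(NC(=O)Nc3ccccc3Cl)cc2)nc2ccsc12` differs from compound 2 by a diethylamino in place of a dimethylamino on the chain, and in this assay compound 3 gives 620 nM, a step of a 2.0-fold higher number from compound 2 to compound 3 (0.30 log units; within the scatter); how compound 3 differs from compound 1 is not broken down here. Compound 4 `CCN(CC)CCNc1nc(-c2ccc(NC(=O)Nc3ccc(Cl)cc3Cl)cc2)nc2ccsc12` differs from compound 3 by chloro in place of hydrogen on an aromatic carbon. This is the same kind of change as from compound 1 to compound 2, but not the same: there the new chloro sat ortho to a large group, here it sits meta to a chloro group and para to a large group. Because a 2.0-fold lower number from compound 1 to compound 2 (0.30 log units; within the scatter) stayed within the scatter, compound 4 is expected to move by about a 1.6-fold lower number from compound 3 to compound 4 (0.19 log units; within the scatter). Compound 4 is estimated at 400 nM, expected between 200 nM and 1000 nM.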

Compound 4, half-maximal inhibitory concentration: 1940 nM
Compound 4: the middle estimate sits 4.9-fold (0.69 log units) below what was measured; the whole stated range lies below it.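

Turning 2-chlorophenyl into 2,4-dichlorophenyl gives a 3.1-fold higher number from compound 3 to compound 4 (0.50 log units; beyond the scatter) in this assay. Adding a chloro therefore does not carry over as one fixed step in this series, as the two cases set side by side show: the same change on two cores in this assay, a 2.0-fold lower number (0.30 log units; within the scatter) from compound 1 to compound 2 and a 3.1-fold higher number (0.50 log units; beyond the scatter) from compound 3 to compound 4, 6.3-fold (0.80 log units) apart, beyond the scatter of two such steps This comparison does not show what separates the two cases, which differ both in where the chloro enters and in the amine on the chain, dimethylamino in one and diethylamino in the other.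

The compounds shown leave open how 2,4-dichlorophenyl would read with dimethylamino on the chain, a comparison that would separate those two differences. They also leave open whether a methoxy group in place of the new chloro would raise the number as well.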